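The source may report more compounds than this note shows. Statements on the series, on what has been measured and on what is new or still open speak of the compounds shown alone.

In a functional assay on MDA-MB-435 cells (Homo sapiens) for cytotoxicity, read by sulforhodamine B assay (a higher number here means a weaker inhibitor, a lower number a stronger inhibitor), compound 2 `C=C1C(=O)O[C@@H]2[C@@H]1C[C@H]1O[C@]1(CO)CC/C=C(\C)CC/C=C(\C)[C@H]2O` gives 8 ug/mL, the only number among the two results shown. Compound 1 `C=C1C(=O)O[C@@H]2[C@@H]1C[C@H](O)[C@@](O)(CO)CC/C=C(\C)CC/C=C(\C)[C@@H]2O` reaches only a limit of this assay, > 10 ug/mL, which is a limit and not a number; the limit of > 10 ug/mL in this assay, at which 1 of the 2 values shown sits, marks where it sits. Compound 3 `C=C1C(=O)O[C@@H]2[C@@H]1C[C@H]1O[C@]1(CO)CC/C=C(\C)CC/C=C(\C)[C@@H]2O` differs from compound 2 in that (the two compounds have the same atoms and bonds and differ only in configuration as drawn: 1 of 7 stereo elements differ; a stereocentre at a saturated ring carbon is drawn R in compound 2 and S in compound 3). Within the data shown here, no step between measured compounds is available, so with one configuration changed the expected step in this assay is no change at the digits printed from compound 2 to compound 3 (within the scatter), nothing beyond the scatter. Compound 3 is therefore estimated at 8 ug/mL, between 3 ug/mL and 20 ug/mL.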

Compound 3, half-maximal inhibitory concentration: 7.7 ug/mL
The estimate for compound 3 lay 1.0-fold (0.02 log units) above the measured number; the range from low to high includes it.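

Changing the configuration at the saturated ring carbon from R to S gives a 1.0-fold lower number from compound 2 to compound 3 (0.02 log units; within the scatter) in this assay. Among these compounds, this is the first single change that can be read, and at this stereocentre the two drawn configurations give values within the scatter of each other. The comparison is a clean one, with a single difference: the fact that compounds 2 and 3 differ only in the configuration as drawn

The compounds shown leave open whether this holds at the other stereocentres. They also leave open how the number would respond if an acetate ester or an amine replaced a hydroxyl group.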